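A few compounds are considered here, and "the series" means these few. Any claim that something is new, unique, unknown or untested is made for them only; others in the source may bear on it.

Measured compounds:
Compound 1 `C=CCc1cc(C(=O)Nc2cc3ccc(OC4CCN(C)CC4)c(C)c3oc2=O)ccc1OC(C)=O` gives 2260 nM in a functional assay on SK-BR-3 cells (Homo sapiens) for antiproliferative activity; on this read-out lower numbers stand for stronger inhibition and higher numbers for weaker inhibition.
Compound 2 `CC(=O)Oc1ccc(C(=O)Nc2cc3ccc(OC4CCN(C)CC4)c(C)c3oc2=O)cc1` gives 1670 nM in this assay.
Compound 3 `C=CCc1cc(C(=O)Nc2cc3ccc(OC4CCN(C)CC4)c(C)c3oc2=O)ccc1O` gives 2430 nM in this assay.

Compound 4 `Cc1c(OC2CCN(C)CC2)ccc2cc(NC(=O)c3ccc(O)cc3)c(=O)oc12` has not yet been measured. The three measured compounds share a core and differ only in the amide-bound aryl group. The step of a 1.4-fold lower number from compound 1 to compound 2 (0.13 log units; within the scatter) comes from the change (hydrogen in place of allyl on an aromatic carbon). The step of a 1.1-fold higher number from compound 1 to compound 3 (0.03 log units; within the scatter) comes from the change (hydrogen in place of acetyl on an oxygen on an aromatic ring). The remaining pair, the step of a 1.5-fold higher number from compound 2 to compound 3 (0.16 log units; within the scatter), comes from the larger exchange at the carbonyl carbon. All three steps stay within the scatter, so the three values are not distinguished from one another.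

Compound 4 arises from compound 3 by the change (hydrogen in place of allyl on an aromatic carbon). The same structural change, hydrogen in place of allyl on an aromatic carbon, has already been made once, from compound 1 to compound 2, where it gave the step of a 1.4-fold lower number from compound 1 to compound 2 (0.13 log units; within the scatter). The two cores differ by hydrogen in place of acetyl on an oxygen on an aromatic ring, so the surroundings of the change are not identical: in compound 1 the aromatic carbon is ortho to an acetoxy group (4 heavy atoms), in compound 3 it is ortho to a hydroxy group (1 heavy atom). The change from compound 3 to compound 4 is therefore the same kind of change, not the same change.

Because the earlier step of a 1.4-fold lower number from compound 1 to compound 2 (0.13 log units; within the scatter) stayed within the scatter, compound 4 is expected to give a step of about a 1.3-fold lower number from compound 3 to compound 4 (0.11 log units; within the scatter) in this assay. The expected value for compound 4 is 1900 nM, with a range from 900 nM to 4000 nM.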

Compound 4, half-maximal inhibitory concentration: 840 nM
For compound 4 the middle estimate is 2.3-fold (0.35 log units) above the measured one; measured number outside the range, below it.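

For the compounds shown here, removing the allyl group gives a 2.9-fold lower number from compound 3 to compound 4 (0.46 log units; beyond the scatter) in this assay, and this step can be set beside the one made by the same exchange on the core of compound 1, where the acetyl group is still present: the same change on two cores in this assay, a 1.4-fold lower number (0.13 log units; within the scatter) from compound 1 to compound 2 and a 2.9-fold lower number (0.46 log units; beyond the scatter) from compound 3 to compound 4, 2.1-fold (0.33 log units) apart, within the scatter of two such steps Removing the acetyl group from the hydroxy oxygen gives a 2.0-fold lower number from compound 2 to compound 4 (0.30 log units; within the scatter), and the same exchange can be compared on the two cores, with and without the allyl group: the same change on two cores in this assay, a 1.1-fold higher number (0.03 log units; within the scatter) from compound 1 to compound 3 and a 2.0-fold lower number (0.30 log units; within the scatter) from compound 2 to compound 4, 2.1-fold (0.33 log units) apart, within the scatter of two such steps Each change is therefore compatible with carrying over from one core to the other, even though only the step from compound 3 to compound 4 passes beyond the scatter, but with a single pair of cores for each change this does not show that either step keeps its size, nor does it show that the two cores truly respond alike or differently.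

The compounds shown leave open how a propyl chain or a longer chain in place of the allyl group, or a methoxy group or an amine in place of the hydroxy group, would read in this assay. On these data alone, whether these steps would hold on any other core or in any other read-out also remains open.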